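A Bromophenyl Ketone Returns to the Side Chain of Compound 2

The compounds below may be only part of what the source reports. "The series", "measured", "known", "first", "only" and "open" are said of these compounds alone.

Compound 1 `COc1cc(-c2nnc(SCC(=O)c3ccc(C)cc3)n2N2C(=O)c3ccccc3C2=O)cc(OC)c1OC` and compound 2 `COc1cc(-c2nnc(SCc3ccccc3)n2N2C(=O)c3ccccc3C2=O)cc(OC)c1OC` share one core and differ only in the group on a saturated chain carbon bound to a sulfur. In a functional assay on PC-3M cells (Homo sapiens) for cytotoxicity, read by MTT assay, with a stated time of 48 h (a lower number here means a stronger inhibitor, a higher number a weaker inhibitor), compound 1 gives 11700 nM. For compound 2 this assay reports only a limit, > 200000 nM, and not a number. Among the compounds with values here, the single measured step, an at least 17-fold higher number from compound 1 to compound 2 (1.23 log units; beyond the scatter), shows that exchanging the aryl carbonyl for a bare phenyl weakened the inhibitor, and the limit of > 200000 nM in this assay, at which 1 of the 2 values shown sits, marks where compound 2 sits among the two values. Compound 3 `COc1cc(-c2nnc(SCC(=O)c3ccc(Br)cc3)n2N2C(=O)c3ccccc3C2=O)cc(OC)c1OC` reverses that direction: (4-bromophenyl)carbonyl in place of phenyl on a saturated chain carbon bound to a sulfur. Since this change runs opposite to the measured step, a large fall in number from compound 2 to compound 3 is expected, bringing compound 3 close to compound 1. Compound 3 is therefore estimated at 12000 nM, within 4000 nM to 40000 nM, a step of an at least 16-fold lower number from compound 2 to compound 3 (1.22 log units; beyond the scatter).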

Compound 3, half-maximal inhibitory concentration: 22600 nM
Compound 3: middle estimate off by 1.9-fold (0.27 log units), on the low side, within the range that was stated.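

In this assay, putting a carbonyl back on the side chain, now with a bromo-bearing ring, gives an at least 8.8-fold lower number from compound 2 to compound 3 (0.94 log units; beyond the scatter), so the effect seen with the (4-methylphenyl)carbonyl group is not confined to that one group. Bromo in place of methyl on an aromatic carbon gives a 1.9-fold higher number from compound 1 to compound 3 (0.29 log units; within the scatter), so the two aryl ketones cannot be told apart here. Compound 2 remains a limit and not a number, so the size of its step stays a bound: the limit of > 200000 nM in this assay, at which 1 of the 3 values shown sits.

The compounds shown do not separate the part played by the carbonyl from that of the ring substituent. On these data alone, what a (4-methoxyphenyl)carbonyl group, a (4-aminophenyl)carbonyl group or a longer chain on the sulfur would give in this assay stays open.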